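The source may report more compounds than this note shows. Statements on the series, on what has been measured and on what is new or still open speak of the compounds shown alone.

In a functional assay on P388 cells (Mus musculus) for inhibition (a lower number here means a stronger inhibitor, a higher number a weaker inhibitor), compound 1 (`O=C1/C(=C/c2cccc(Cl)c2)Cc2ccccc21`) gives 26300 nM and compound 2 (`O=C1/C(=C/c2ccc(Br)cc2)CCc2ccccc21`) gives 20400 nM as its reading. Compound 2 therefore stands level with compound 1, since the two numbers lie within the usual scatter of each other and neither can be ranked ahead. Going by the values given here, no step between closely matched measured compounds is available, so the data hold no direct precedent for the next change. Compound 3 (`CN(C)c1ccc(/C=C2\CCc3ccccc3C2=O)cc1`) differs from compound 2 in one place, through the change dimethylamino in place of bromo on an aromatic carbon in which dimethylamino stands in place of bromo on an aromatic carbon, para to a large group. Among the compounds with values here, nothing measured so far shows which way such a swap would move the number, and so no step beyond the scatter is expected in this assay for this pair. The estimated step of a 1.1-fold lower number from compound 2 to compound 3 (0.05 log units; within the scatter) is accordingly small, and its direction remains uncertain. For compound 3 the expected value is 18000 nM with 6000 nM to 50000 nM as the estimated range.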

Compound 3, half-maximal inhibitory concentration: 5300 nM
Compound 3: middle estimate off by 3.4-fold (0.53 log units), on the high side; measured number below the stated range.
By their numbers in this assay, from the lowest: compound 3; then compounds 2 and 1 (each within the scatter of the next).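

In this assay, going by these compounds alone, putting dimethylamino in place of bromo on an aromatic carbon, para to a large group, gives a 3.8-fold lower number from compound 2 to compound 3 (0.59 log units; beyond the scatter), the first step that can be read between compounds differing in one place. It shows that the number responds to what this position carries: exchanging bromo for dimethylamino, with 3 heavy atoms and 1 hydrogen-bond acceptor in place of 1 heavy atom and none, moves it beyond the scatter, although this rests on a single pair. Nothing at hand shows which feature of the exchange accounts for the step.

The compounds shown leave open whether the lower number is specific to dimethylamino or would also appear with a primary amine, a methoxy group, or a cyclic amine such as pyrrolidine or morpholine at the same place. They also leave open whether the same exchange would produce a step of similar size on the core of compound 1, or with dimethylamino moved to another carbon of the same aromatic ring.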